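A few compounds are considered here, and "the series" means these few. Any claim that something is new, unique, unknown or untested is made for them only; others in the source may bear on it.

Compound 1 `N#CCOc1ccc2nccc(SC3(C(=O)O)CCC3)c2c1` is the weaker of the two compounds measured here. In an assay on HEK293 cells for inhibition of solute carrier family 22 member 12 (Homo sapiens), read by scintillation counting, with a stated time of 12 min (on this read-out lower numbers stand for stronger inhibition and higher numbers for weaker inhibition), compound 1 gives 680 nM, whereas compound 2 `O=C(O)C1(Sc2ccnc3cc(Br)ccc23)CCC1` gives 130 nM in this assay, a gap that lies beyond the usual scatter of this kind of measurement. Compound 2 carries a bromine on its core in place of the cyanomethoxy group of compound 1, but since more than one thing changes between the two, their values can only be read side by side, not as a single step.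

Compound 3 `O=C(O)C1(Sc2ccnc3ccc(-c4ccc(F)cc4)cc23)CCC1` keeps the shared core and the acid-bearing ring of compound 1 but differs in one place: 4-fluorophenyl in place of cyanomethoxy on an aromatic carbon. Among the compounds with values here, no measured pair shows this exact exchange, so what follows is an expectation rather than a reading of data. Given that the only other substituent tried on the core, in compound 2 with 130 nM, sits well below compound 1, a moderate move toward a lower number is expected for compound 3, a 2.7-fold lower number from compound 1 to compound 3 (0.43 log units; beyond the scatter), though with considerable uncertainty. In this assay compound 3 is therefore estimated at 250 nM, within a range from 60 nM to 1000 nM.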

Compound 3, half-maximal inhibitory concentration: 159 nM
Beside the measured number, compound 3's estimate is 1.6-fold (0.20 log units) above it, within the range that was stated.
By their numbers in this assay, from the lowest: compounds 2 and 3 (each within the scatter of the next); then compound 1.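

Within the data shown here, this is the first change in one place that can be read directly: in this assay, putting 4-fluorophenyl in place of cyanomethoxy gives a 4.3-fold lower number from compound 1 to compound 3 (0.63 log units; beyond the scatter). It shows that this aromatic carbon of the shared core tolerates a group with more heavy atoms and an added aromatic ring, and that inhibition on this read-out does not depend on keeping the triple bond or the hydrogen-bond acceptors of cyanomethoxy. No measurement here explains why the number falls, so the step stands only as an observation.

The compounds shown leave open whether the gain comes from the aromatic ring itself or from its fluorine, which a plain phenyl group at the same carbon would help to separate. They also leave open whether an aromatic ring is needed at all, a question that a saturated ring such as cyclohexyl, or an amine such as morpholine, at this carbon could begin to answer.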